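This account rests on a few compounds, and the source may have more. Where it says the series, first, only, none or still open, it means among the compounds named here.

Measured compounds in the series:

- compound 1 `CN(Cc1nc2cc(C(F)(F)F)ccc2nc1-c1ccccc1)c1ccc(Cl)cc1` — in an assay on isolated protein for inhibition of Dihydrofolate reductase (Homo sapiens), read by spectrophotometry (a higher number here means a weaker inhibitor, a lower number a stronger inhibitor), compound 1 gives 5000 nM
- compound 2 `CN(Cc1nc2cc(C(F)(F)F)ccc2nc1-c1ccccc1)c1ccc(F)cc1` — in this assay compound 2 gives 5000 nM
- compound 3 `COc1ccc(N(C)Cc2nc3cc(C(F)(F)F)ccc3nc2-c2ccccc2)cc1` — in this assay compound 3 gives 3000 nM

Among the compounds with values here, compound 1 and compound 2 share the same number, and compound 3 sits apart from both only within the scatter; no compound among the three can be separated from the others beyond it. The exchange of the halogen, no change at the digits printed from compound 1 to compound 2 (within the scatter), leaves the number untouched, while the two steps to the methoxy compound, a 1.7-fold lower number from compound 1 to compound 3 (0.22 log units; within the scatter) and a 1.7-fold lower number from compound 2 to compound 3 (0.22 log units; within the scatter), both fall inside the scatter.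

Compound 4 `COc1ccc(N(C)Cc2nc3cc(C(F)(F)F)ccc3nc2-c2ccccc2)cc1OC` is not yet measured. It differs from compound 1 by 3,4-dimethoxyphenyl in place of 4-chlorophenyl on an amine nitrogen. Within the data shown here, the nearest measured step is the single methoxy substitution from compound 1 to compound 3, which moved the number only within the scatter; the second methoxy group has no counterpart among the measured compounds. The expectation is therefore a number close to compound 3, with the step of a 1.7-fold lower number from compound 1 to compound 4 (0.22 log units; within the scatter) expected to stay within the scatter.

Estimate for compound 4 in this assay: 3000 nM, expected range 1500 nM to 8000 nM.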

Compound 4, inhibition constant: 8000 nM
The estimate for compound 4 lay 2.7-fold (0.43 log units) below the measured number, and the stated range covers the measured number.
By their numbers in this assay, from the lowest: compounds 3, 1, 2 and 4 (each within the scatter of the next, the first and the last beyond it).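

In this assay, within the data shown here, adding a second methoxy group gives the only step so far that lies beyond the scatter, though a modest one (a 2.7-fold higher number from compound 3 to compound 4 (0.43 log units; beyond the scatter)). Among these compounds, the 3,4-dimethoxyphenyl group does not separate from either halogenated aryl group (a 1.6-fold higher number from compound 1 to compound 4 (0.20 log units; within the scatter); a 1.6-fold higher number from compound 2 to compound 4 (0.20 log units; within the scatter)), so any reading of this position as sensitive rests on the single pair of compound 3 and compound 4. The data give no account of why the second methoxy group goes with this step.

Still open, going by these compounds, is whether the step belongs to methoxy specifically or would recur with another group on the aryl ring, such as a hydroxyl, an amine or a carboxylic acid. Also open, on these data alone, is whether the aromatic group on the amine nitrogen can move the number further than the compounds here do, for which a longer chain in place of the methyl on that nitrogen would be a separate test.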